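A few compounds are considered here, and "the series" means these few. Any claim that something is new, unique, unknown or untested is made for them only; others in the source may bear on it.

Values in a functional assay on CNE-2 cells (Homo sapiens) for inhibition, read by MTT assay, with a stated time of 72 h; on this read-out lower numbers stand for stronger inhibition and higher numbers for weaker inhibition:
- compound 1 `Nc1ncnc2c1c(-c1cnc3[nH]ccc3c1)nn2CCCCCCCCC(=O)NO`: 2270 nM
- compound 2 `Nc1ncnc2c1c(-c1cnc3[nH]ccc3c1)nn2CCCCC(=O)NO`: > 150000 nM (a limit)
- compound 3 `Nc1ncnc2c1c(-c1cnc3[nH]ccc3c1)nn2CCCCCC(=O)NO`: > 50000 nM (a limit)

Compound 3 has no number, only the limit > 50000 nM. Its standing therefore rests on (the limit of > 50000 nM in this assay, at which 1 of the 3 values shown sits). Compound 2 is also known only as a limit, at > 150000 nM. This leaves a step that the two limits leave unreadable from compound 2 to compound 3 without a usable size. Compound 1 is the only one of the three with a number, at 2270 nM.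

The next compound is compound 4 `Nc1ncnc2c1c(-c1cnc3[nH]ccc3c1)nn2CCCCCCC(=O)NO`. The change is (hydroxycarbamoyl)methyl in place of hydroxycarbamoyl on a saturated chain carbon, five bonds along the chain from an aromatic nitrogen. This gives compound 4 a chain longer than that of compound 3 and shorter than that of compound 1.

Within the data shown here, the steps that bear on this are an at least 22-fold higher number from compound 1 to compound 3 (1.34 log units; beyond the scatter) and an at least 66-fold higher number from compound 1 to compound 2 (1.82 log units; beyond the scatter). Both are large and both run to a higher number as the chain shortens from that of compound 1. Read in reverse, they point to a lower number in this assay for the longer chain of compound 4, though only part of the way towards compound 1. A single added chain unit is expected to give a moderate step, and another limit remains possible. The expected step is an at least 2.5-fold lower number from compound 3 to compound 4 (0.39 log units; beyond the scatter). For compound 4 the estimated value is 20000 nM, with an expected range of 6000 nM to 70000 nM.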

Compound 4, half-maximal inhibitory concentration: 19500 nM
Beside the measured number, compound 4's estimate is 1.0-fold (0.01 log units) above it, and the stated range covers the measured number.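

In this assay, compound 4 is the only chain shorter than that of compound 1 to carry a number rather than a limit, which gives the loss on shortening its first measured size: an 8.6-fold higher number from compound 1 to compound 4 (0.93 log units; beyond the scatter). Against the two shorter chains the number falls, with an at least 2.5-fold lower number from compound 3 to compound 4 (0.40 log units; beyond the scatter) and an at least 7.6-fold lower number from compound 2 to compound 4 (0.88 log units; beyond the scatter), so the number drops stepwise across compound 3, compound 4 and compound 1, while the step from compound 2 to compound 3 cannot be read and does not show whether compound 2 fits this pattern. Both of these sizes are minimum sizes, and the one from compound 3 rests on a limit, not a number: the limit of > 50000 nM in this assay, at which 1 of the 4 values shown sits.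

Compound 1 carries the longest chain shown, so it remains open whether a longer chain would lower the number further or raise it again, and how the number runs over the chain lengths between compound 4 and compound 1. All four compounds end in the same hydroxycarbamoyl group, so a carboxylic acid or a primary amide at the chain end would be needed to tell what that group contributes at each length.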